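The compounds below may be only part of what the source reports. "The series", "measured", "known", "first", "only" and "open" are said of these compounds alone.

Measured so far:
compound 1 `O=C(/C=C/c1ccc(O)cc1)c1c(O)cccc1OCCC1CCCC1` — 3480 nM
compound 2 `CC(C)(C)CCOc1cccc(O)c1C(=O)CCc1ccc(O)cc1` — > 30000 nM

Among the compounds with values here, in a functional assay on PC-3 cells (Homo sapiens) for antiproliferative activity, read by sulforhodamine B assay (a higher number here means a weaker inhibitor of growth, a lower number a stronger inhibitor of growth), compound 1 gives 3480 nM, the only actual number among the two values in hand. Compound 2 reports > 30000 nM, which is a limit of the assay rather than a number (the limit of > 30000 nM in this assay, at which 1 of the 2 values shown sits). Within the data shown here, compound 2 differs from compound 1 in more than one place, so its limit says nothing about the single change followed here.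

Compound 3 `CCCCOc1cccc(O)c1C(=O)/C=C/c1ccc(O)cc1` has not yet been measured in this assay. Its difference from compound 1: ethyl in place of cyclopentyl on a saturated chain carbon, two bonds along the chain from an oxygen on an aromatic ring. Among the measured compounds shown here, no measured pair isolates this change, so the expectation rests on compound 1 alone. The step of a 1.7-fold higher number from compound 1 to compound 3 (0.24 log units; within the scatter) is expected to be small, toward weaker growth inhibition, and not clearly beyond the scatter. Compound 3 is estimated at 6000 nM in this assay, within a range of 2500 nM to 15000 nM.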

Compound 3, concentration for 50% growth inhibition: > 30000 nM
Compound 3 gave a limit, no number (the forecaster's own chance of this, stated with the estimate: 10%); at least 5.0-fold (0.69 log units) between middle value and limit.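

In this assay, replacing cyclopentyl with ethyl at this place on the side chain, which reads as 2-cyclopentylethoxy to butoxy, gives an at least 8.6-fold higher number from compound 1 to compound 3 (0.93 log units; beyond the scatter). The end of this chain is therefore not indifferent to change: of this matched pair, only compound 1, with the cyclopentyl, gives a number, 3480 nM. Compound 3 stands at a limit, not a number: the limit of > 30000 nM in this assay, at which 2 of the 3 values shown sit.

This single step removes the ring and shortens the group together, and the compounds shown do not separate those two changes. A pentyl or cyclohexyl group at this place would show whether the ring, its size or the carbon count carries the difference.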